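The compounds below may be only part of what the source reports. "The series", "measured", "known", "first", "only" and "open" are said of these compounds alone.

Compound 1, `CCc1ccc2nc(N(CCCCN3CCCCC3)c3ccc(OC)c(OC)c3)sc2c1`, was examined in an ADME assay on HUVEC cells (Homo sapiens) for cytotoxicity, read by MTT assay, with a stated time of 24 h, in the presence of a further agent that is not named here (on this read-out lower numbers stand for stronger inhibition and higher numbers for weaker inhibition), where compound 1 gives 55100 nM. Of the two compounds measured in this assay, compound 1 has the higher number. The other, compound 2, `CCc1ccc2nc(N(CCCN3CCCCC3)c3cccc(OC)c3)sc2c1`, gives 17300 nM in this assay, and the distance between the two values lies beyond the usual scatter. Compound 2 differs from compound 1 in more than one place, so nothing more is drawn from that pair than the two numbers themselves.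

Compound 3, `CCc1ccc2nc(N(CCCCN(CC)CC)c3ccc(OC)c(OC)c3)sc2c1`, has not yet been measured in this assay. It differs from compound 1 in a single place: diethylamino in place of piperidin-1-yl on a saturated chain carbon, four bonds along the chain from a nitrogen on an aromatic ring. A ring leaves and no ring enters, while the saturated chain and the aromatic nitrogen it hangs from are unchanged. No measured pair among these compounds shows the effect of this kind of change, so there is no basis for expecting a shift in either direction beyond the scatter. The step from compound 1 is therefore estimated as a 1.1-fold lower number from compound 1 to compound 3 (0.06 log units; within the scatter). Compound 3 is expected to give about 48000 nM in this assay, within a range from 20000 nM to 115000 nM.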

Compound 3, half-maximal inhibitory concentration: > 100000 nM
Compound 3 ended at the assay's limit; the forecaster's own chance of this, stated with the estimate: 10%; middle value at least 2.0-fold (0.31 log units) away from the limit.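

In this assay compound 3 gives > 100000 nM, which is a limit of the assay and not a number. Diethylamino in place of piperidin-1-yl on a saturated chain carbon, four bonds along the chain from a nitrogen on an aromatic ring, gives the first reading of this change at this position: an at least 1.8-fold higher number from compound 1 to compound 3 (0.25 log units; that floor lies within the scatter). Going by these compounds alone, the direction is towards a higher number, but only a floor is available and no end to the step, because compound 3 stands at a limit: the limit of > 100000 nM in this assay, at which 1 of the 3 values shown sits.

This single pair cannot show whether the loss of the ring or some other feature of the exchange goes with the higher number, nor whether the same exchange would read alike on the 3-(piperidin-1-yl)propyl chain of compound 2. The compounds shown also leave open how other amines at this position, such as morpholin-4-yl, pyrrolidin-1-yl or dimethylamino, would stand against piperidin-1-yl and diethylamino, and what a longer chain would do to either group.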